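Acetyl for methyl on the pyrazole nitrogen of compound 1

The source may report more compounds than this note shows. Statements on the series, on what has been measured and on what is new or still open speak of the compounds shown alone.

The three measured compounds share a core and differ in the group carried on the amide-linked aromatic ring. Compound 1 `CNC(=O)N1CCCc2ccc(NC(=O)c3cccc(-c4ccn(C)n4)c3)cc21` gives 70.5% in a functional assay on MV4-11 cells (Homo sapiens) for antiproliferative activity, with a stated time of 6 days, tested at 1.56 uM (a lower number here means a weaker effect, a higher number a stronger effect of the compound at the concentration tested), the second highest of the three numbers. Compound 2 `CNC(=O)N1CCCc2ccc(NC(=O)c3ccc(-c4cnn(C)c4)cc3)cc21` gives 77.4%, within the scatter of compound 1, while compound 3 `CNC(=O)N1CCCc2ccc(NC(=O)c3ccc(-c4ccn(C(C)=O)n4)cc3)cc21` gives 35.8%, beyond the scatter below compound 1.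

The unmeasured compound 4 `CNC(=O)N1CCCc2ccc(NC(=O)c3cccc(-c4ccn(C(C)=O)n4)c3)cc21` arises from compound 1 by a single change: acetyl in place of methyl on an aromatic nitrogen. Within the data shown here, the one measured step that bears on this is the move from compound 2 to compound 3, which also introduces an acetyl on the aromatic nitrogen of the five-membered aromatic ring with 2 nitrogen, though combined with a change in the attachment point of that ring; it gave a number 41.6 percentage points lower from compound 2 to compound 3 (beyond the scatter). Since compound 1 and compound 2 stand within the scatter of each other, a similar large drop is expected for compound 4, though its exact size is uncertain as the earlier step mixed two changes.

Compound 4 is therefore estimated at 35%, within 15% to 55%, an expected step of a number 35.5 percentage points lower from compound 1 to compound 4 (beyond the scatter).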

Compound 4, a percentage reported as inhibition, at one concentration (the size of the read-out at that concentration, not a potency): 27.6%
Estimate against measurement, compound 4: 7.4 percentage points above; the range from low to high includes it.
By their numbers in this assay, from the lowest: compounds 4 and 3 (each within the scatter of the next); then compounds 1 and 2 (each within the scatter of the next).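

The change from 1-methyl-1H-pyrazol-3-yl to 1-acetyl-1H-pyrazol-3-yl now stands alone, with no shift in the attachment point of the ring, and in this assay it gives a number 42.9 percentage points lower from compound 1 to compound 4 (beyond the scatter). The loss therefore does not depend on a change of attachment point, and acetyl on this aromatic nitrogen is enough to produce a large step on its own. Compound 3, which carries the same 1-acetyl-1H-pyrazol-3-yl group at another place on the amide-linked aromatic ring, gives 35.8% and compound 4 gives 27.6%, two values within the scatter of each other, and nothing measured here says why acetyl costs so much at this nitrogen.

The compounds shown leave open whether the loss follows the carbonyl of the acetyl or the larger size of the group, which an ethyl or an isopropyl group on the same nitrogen, or a pyrazole with a free ring hydrogen there, would help to separate. They also leave open how a dimethylcarbamoyl or methanesulfonyl group on this nitrogen would stand against methyl and acetyl.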